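Cytotoxicity limits in the aryl ether series: compound 3

The compounds below may be only part of what the source reports. "The series", "measured", "known", "first", "only" and "open" are said of these compounds alone.

Measured so far:
compound 1, `CCC(C)Oc1ccc(C(O)C2OC(=O)c3c(OC)cc(OC)cc32)cc1`: > 40000 nM
compound 2, `C=CCCOc1ccc(C(O)C2OC(=O)c3c(OC)cc(OC)cc32)cc1`: > 40000 nM

In an ADME assay on RAW264.7 cells (Mus musculus) for cytotoxicity, read by MTT assay, with a stated time of 24 h, in the absence of a further agent (on this read-out lower numbers stand for stronger inhibition and higher numbers for weaker inhibition), compound 2 gives only a limit, > 40000 nM. Compound 1 also gives only a limit, > 40000 nM. For the measured compounds named here, both sit at the limit of > 40000 nM in this assay, at which 2 of the 2 values shown sit, so the one measured step, a step that the two limits leave unreadable from compound 1 to compound 2, has no readable size.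

Compound 3, `COc1cc(OC)c2c(c1)C(C(O)c1ccc(OCC3CCCCC3)cc1)OC2=O`, carries cyclohexyl in place of allyl on a saturated chain carbon bound to an oxygen on an aromatic ring. Going by the values given here, no measured step bears on this change with a readable size. The expected step is a step that the limit leaves unreadable from compound 2 to compound 3, nothing beyond the scatter, with a limit again likely. Compound 3 is therefore estimated at 50000 nM, within 20000 nM to 150000 nM.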

Compound 3, half-maximal inhibitory concentration: > 40000 nM
Compound 3: only a limit was reported; the forecaster's own chance of this, stated with the estimate: 75%; the middle value does not contradict the limit.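

No step among compound 1, compound 2 and compound 3 can be read, since all three values are limits: the limit of > 40000 nM in this assay, at which 3 of the 3 values shown sit.

The compounds shown leave open whether any change of the group on this oxygen gives a readable value.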